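Chloro to bromo on the tosylate-bearing triazole analogue

The source may report more compounds than this note shows. Statements on the series, on what has been measured and on what is new or still open speak of the compounds shown alone.

The compounds share one core. Compound 1 `Cc1c(O)ccc2c1[C@H](Cn1cc(-c3ccc(Cl)cc3)nn1)[C@@]13CC(=O)[C@@](C)(CC[C@@H]21)C3` carries a free phenolic oxygen. In a functional assay on SW480 cells (Homo sapiens) for cytotoxicity, read by MTT assay, with a stated time of 4 days (on this read-out lower numbers stand for stronger inhibition and higher numbers for weaker inhibition), compound 1 gives only a limit of the assay, > 20000 nM. Compound 2 `Cc1ccc(S(=O)(=O)Oc2ccc3c(c2C)[C@H](Cn2cc(-c4ccc(Cl)cc4)nn2)[C@@]24CC(=O)[C@@](C)(CC[C@@H]32)C4)cc1` carries the (4-methylphenyl)sulfonyl on that oxygen. In this assay compound 2 also gives a limit, > 20000 nM. The step that the two limits leave unreadable from compound 1 to compound 2 is therefore not readable. Compound 3 `C=C1C[C@]23C[C@@]1(O)CC[C@H]2c1ccc(O)c(C)c1[C@@H]3Cn1cc(-c2ccc(F)cc2)nn1`, built on a different core and carrying a 4-fluorophenyl triazole, gives in this assay a limit as well, > 20000 nM. Compound 2 thus stands, like every compound measured here, at the limit of > 20000 nM in this assay, at which 3 of the 3 values shown sit; nothing on the numbers shown separates it from the others.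

Compound 4 `Cc1ccc(S(=O)(=O)Oc2ccc3c(c2C)[C@H](Cn2cc(-c4ccc(Br)cc4)nn2)[C@@]24CC(=O)[C@@](C)(CC[C@@H]32)C4)cc1` differs from compound 2 by bromo in place of chloro on an aromatic carbon. For the measured compounds named here, no measured step concerns this halogen exchange; the single measured step, from compound 1 to compound 2, touches the phenolic oxygen and is itself lost between two limits. With every measured value sitting at the limit, neither a direction nor a size for the change can be drawn from the data. Compound 4 is therefore expected to remain at the limit, with an estimated step that the limit leaves unreadable from compound 2 to compound 4 that means nothing beyond the scatter. The estimate for compound 4 is 25000 nM, with a range from 10000 nM to 80000 nM.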

Compound 4, half-maximal inhibitory concentration: > 20000 nM
Compound 4: no number, only a limit; the forecaster's own chance of this, stated with the estimate: 85%; the middle value is on the limit's open side.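

Compound 4 gives only a limit in this assay, > 20000 nM. Compound 2 also gives only a limit, so no step between compound 2 and compound 4 can be read: the limit of > 20000 nM in this assay, at which 4 of the 4 values shown sit.

The compounds shown leave open whether bromo in place of chloro alters cytotoxicity at all, and how any of these compounds ranks against the others.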